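Ester variation across a short series at adenosine receptor A3

A few compounds are considered here, and "the series" means these few. Any claim that something is new, unique, unknown or untested is made for them only; others in the source may bear on it.

Measured so far:
compound 1, `CCOC(=O)C1=C(C)N(C)C(=O)NC1c1cccs1`, 2%
compound 2, `CCCOC(=O)C1=C(C)N(C)C(=O)NC1c1cccs1`, 4%

In an assay on membranes from HeLa cells for displacement of a labelled ligand from adenosine receptor A3 (Homo sapiens), read by scintillation counting, with a stated time of 180 min, tested at 1 uM (a higher number here means more inhibition at the concentration tested (going by the name of the read-out), a lower number less inhibition), compound 2 stands highest of the two numbers, with compound 1 as its nearest neighbour; the step of a number 2 percentage points higher from compound 1 to compound 2 (within the scatter) lies within the scatter, so the two values cannot be ordered. Compound 3, `CC1=C(C(=O)OCc2ccccc2)C(c2cccs2)NC(=O)N1C`, is not yet measured. It differs from compound 2 by phenyl in place of ethyl on a saturated chain carbon bound to an oxygen next to a carbonyl group. Among the measured compounds shown here, the only measured step, a number 2 percentage points higher from compound 1 to compound 2 (within the scatter), bears on the same chain bound to an oxygen next to a carbonyl group and showed no change beyond the scatter. For the measured compounds named here, nothing among the measured compounds speaks to the entry of a six-membered aromatic ring of carbon only at this place, so any expectation rests on the low level of both measured values. The step of a number 4 percentage points higher from compound 2 to compound 3 (within the scatter) is therefore expected to stay within or near the scatter, with a slight upward lean allowed for the larger group. Compound 3 is estimated at 8%, within 0% to 25%.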

Compound 3, a percentage reported as inhibition, at one concentration (the size of the read-out at that concentration, not a potency): 18%
Beside the measured number, compound 3's estimate is 10 percentage points below it; the range from low to high includes it.
By their numbers in this assay, from the lowest: compounds 1 and 2 (each within the scatter of the next); then compound 3.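

In this assay, the change from ethyl to phenyl on the saturated chain carbon bound to an oxygen next to a carbonyl group gives a number 14 percentage points higher from compound 2 to compound 3 (beyond the scatter), and the change from methyl to phenyl at the same place gives a number 16 percentage points higher from compound 1 to compound 3 (beyond the scatter). The earlier pair did not separate, so only the entry of the aromatic ring shows that this place can respond at all, though the read-out remains a single-concentration percentage and gives no potency. Nothing at hand accounts for the difference.

As far as these compounds go, whether the aromatic ring itself matters or simply the larger group remains open, and a cyclohexylmethyl ester or a longer chain such as pentyl would separate the two. Also open, from the compounds shown here alone, is how a carboxylic acid or an amide at this place would compare.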